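Swapping a Sulfonyl for a Furoyl Group on Compound 2

A few compounds are considered here, and "the series" means these few. Any claim that something is new, unique, unknown or untested is made for them only; others in the source may bear on it.

Compound 1 `CC(C)=CCOc1cc(=O)n(CCCO)c2c1CC(CC=C(C)C)C(C)(C)C2`: 20.7%
Compound 2 `CC(C)=CCC1Cc2c(OCCCNS(=O)(=O)c3ccc([N+](=O)[O-])cc3)cc(=O)n(CCCO)c2CC1(C)C`: 47.7%

Of the compounds shown here, two sharing one core have been measured. In a functional assay on PANC-1 cells (Homo sapiens) for inhibition, read by MTT assay, with a stated time of 24 h, tested at 10 uM (on this read-out lower numbers stand for less inhibition and higher numbers for more inhibition at the one concentration tested (going by the name of the read-out)), compound 2 gives 47.7% and stands highest of the two numbers. Compound 1 gives 20.7% in this assay, a gap beyond the scatter, so compound 2 is clearly the more inhibiting of the pair.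

Compound 3 `CC(C)=CCC1Cc2c(OCCCNC(=O)c3ccco3)cc(=O)n(CCCO)c2CC1(C)C` has not yet been measured. It keeps the core and the side chain of compound 2 but carries a different group on the amine nitrogen: (furan-2-yl)carbonyl in place of (4-nitrophenyl)sulfonyl on an amine nitrogen. Among the compounds with values here, no single-change step between measured compounds is available to gauge such a swap, so the expectation rests on the two values alone. In this assay a modest step downward from compound 2 to compound 3, a number 11.7 percentage points lower from compound 2 to compound 3 (beyond the scatter), is expected, though a result within the scatter would not be surprising. Compound 3 is estimated at 36%, within 15% to 58%.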

Compound 3, a percentage reported as inhibition, at one concentration (the size of the read-out at that concentration, not a potency): 2.1%
The estimate for compound 3 lay 33.9 percentage points above the measured number; the measured number lies below the stated range.
By their numbers in this assay, from the lowest: compound 3; then compound 1; then compound 2.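

In this assay the group on this amine nitrogen proves decisive: (furan-2-yl)carbonyl in place of (4-nitrophenyl)sulfonyl gives a number 45.6 percentage points lower from compound 2 to compound 3 (beyond the scatter) and leaves little inhibition. Placing 2-(((furan-2-yl)carbonyl)amino)ethyl in place of 2-methylprop-1-en-1-yl on a saturated chain carbon bound to an oxygen on an aromatic ring gives a number 18.6 percentage points lower from compound 1 to compound 3 (beyond the scatter) and shows that a larger side chain does not by itself bring more inhibition. No measured evidence bears on why these changes have these sizes.

The swap from compound 2 to compound 3 replaces both the sulfonyl link and the aromatic ring, so the compounds shown leave open which of the two matters more. A 4-nitrobenzoyl group or a plain phenylsulfonyl group on the same nitrogen would separate the two.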